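The source may report more compounds than this note shows. Statements on the series, on what has been measured and on what is new or still open speak of the compounds shown alone.

Compound 1 `CCCCCC(=O)OC[C@H]1O[C@@H](n2cnc3c(N)ncnc32)[C@H](O)[C@@H]1O` is reported in an assay on COS-7 cells for inhibition of sodium/nucleoside cotransporter 2 (Homo sapiens), read by scintillation counting, in the presence of a further agent that is not named here (on this read-out higher numbers stand for weaker inhibition and lower numbers for stronger inhibition), only as a limit, > 100000 nM. Compound 2 `Nc1ncnc2c1nc(NCCCc1ccccc1)n2[C@@H]1O[C@H](CO)[C@@H](O)[C@H]1O` gives 536000 nM in this assay and holds the only number shown. The entry for compound 1 sits at a limit (the limit of > 100000 nM in this assay, at which 1 of the 2 values shown sits). Compound 3 `Cc1ccccc1CNc1nc2c(N)ncnc2n1[C@@H]1O[C@H](CO)[C@@H](O)[C@H]1O` differs from compound 2 by 2-methylphenyl in place of phenethyl on a saturated chain carbon bound to a nitrogen on an aromatic ring. Within the data shown here, no measured pair shows a step of this kind, so no shift beyond the usual scatter is expected in this assay. Compound 3 is therefore estimated at 400000 nM, within 100000 nM to 1500000 nM. The expected step is a 1.3-fold lower number from compound 2 to compound 3 (0.13 log units; within the scatter).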

Compound 3, half-maximal inhibitory concentration: 65000 nM
Estimate against measurement, compound 3: 6.2-fold (0.79 log units) above; the measured number lies below the stated range.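

In this assay, the place on a saturated chain carbon bound to a nitrogen on an aromatic ring proves sensitive to the group it carries: 2-methylphenyl in place of phenethyl gives an 8.2-fold lower number from compound 2 to compound 3 (0.92 log units; beyond the scatter). Read one bond further out, the change is 3-phenylpropyl to 2-methylbenzyl, so the chain and the methyl change together and this single pair cannot separate them. No measurement shown bears on why the step occurs. On these data alone, it remains open whether unsubstituted benzyl or a longer chain such as 4-phenylbutyl would keep this shift.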